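A Hydroxy Group on the Ring Nitrogen: What to Expect

A few compounds are considered here, and "the series" means these few. Any claim that something is new, unique, unknown or untested is made for them only; others in the source may bear on it.

Compound 1, `O=C(O)c1occc(=O)c1O`, gives 5% in an assay on isolated protein for inhibition of methionine aminopeptidase 2 (Homo sapiens), read by fluorescence, tested at 200 uM; a higher number here means more inhibition at the concentration tested (going by the name of the read-out), a lower number less inhibition.
Compound 2, `Cc1cc(=O)c(O)c(C(=O)O)[nH]1`, gives 0% in this assay.
Compound 3, `Cc1cc(=O)c(O)c(C(=O)O)n1C`, gives 1% in this assay.

All three measured compounds share one core and differ only in what sits on the aromatic nitrogen. Compound 3 stands second highest of the three numbers, but every gap is within the scatter: the step of a number 1 percentage points higher from compound 2 to compound 3 (within the scatter) is small, and the value of compound 1 lies within the scatter of compound 3 as well. So far, none of the measured changes has moved the read-out beyond noise.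

Compound 4, `Cc1cc(=O)c(O)c(C(=O)O)n1O`, carries the next change at the same position: hydroxy in place of methyl on an aromatic nitrogen. Among the compounds with values here, the only measured step that bears on it is a number 1 percentage points higher from compound 2 to compound 3 (within the scatter), the step that put methyl in place of hydrogen on that nitrogen, and it stayed within the scatter. Within the data shown here, no measured step has yet placed a hydroxy group on the nitrogen, so the effect of a donor and acceptor there is untested. On this basis, a step of a number 2 percentage points higher from compound 3 to compound 4 (within the scatter) is expected, nothing beyond the scatter. Compound 4 is therefore estimated to give 3%, with a range from -5% to 12%.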

Compound 4, a percentage reported as inhibition, at one concentration (the size of the read-out at that concentration, not a potency): 32%
Compound 4: middle estimate off by 29 percentage points, on the low side, and the stated range ends below it.
By their numbers in this assay, from the lowest: compounds 2, 3 and 1 (each within the scatter of the next); then compound 4.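

In this assay, the aromatic nitrogen proves to be a place where the read-out can move: hydroxy in place of methyl gives a number 31 percentage points higher from compound 3 to compound 4 (beyond the scatter), and hydroxy in place of hydrogen gives a number 32 percentage points higher from compound 2 to compound 4 (beyond the scatter), while methyl in place of hydrogen had left the number within the scatter. The swap from methyl to hydroxy keeps the count at one heavy atom, so that count does not separate compound 3 from compound 4; the change is an oxygen for a carbon, bringing a hydrogen-bond donor and a hydrogen-bond acceptor. Nothing available explains why this change has such a large effect.

On these data alone, it remains open whether a methoxy or an amino group on the same nitrogen would give a similar number. As far as these compounds go, it is also open whether the higher number holds if an amide replaces the carboxy group.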